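Compound 4 versus compound 2 in Vero cell tolerance

This account rests on a few compounds, and the source may have more. Where it says the series, first, only, none or still open, it means among the compounds named here.

In an ADME assay on Vero cells (Chlorocebus sabaeus) for cytotoxicity (a higher number here means that more compound is tolerated, a lower number that less compound is tolerated), compound 1 `O[C@@H]1Cc2ccccc2N[C@H](c2cccs2)C1` gives 986000 nM, compound 2 `Cc1ccsc1[C@@H]1C[C@H](O)Cc2ccccc2N1` gives 616000 nM and compound 3 `Cc1ccsc1[C@@H]1C[C@H](O)Cc2cc(F)ccc2N1` gives 243000 nM. Compound 2 thus holds the second highest of the three numbers; the smaller gap is a 1.6-fold lower number from compound 1 to compound 2 (0.20 log units; within the scatter), the larger is a 2.5-fold lower number from compound 2 to compound 3 (0.40 log units; beyond the scatter). Compound 4 `Cc1ccc([C@@H]2C[C@H](O)Cc3ccccc3N2)o1` differs from compound 2 by 5-methylfuran-2-yl in place of 3-methylthiophen-2-yl on a saturated ring carbon, a like-for-like exchange of one five-membered aromatic ring with 1 hetero atom for another. Neither measured step replaces this ring: one adds methyl to it, the other adds fluoro to the core. Within the data shown here, no step bears directly, so in this assay no change beyond the scatter is expected for compound 4, a 1.1-fold lower number from compound 2 to compound 4 (0.05 log units; within the scatter). Compound 4 is estimated at 550000 nM, range 250000 nM to 1200000 nM.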

Compound 4, half-maximal cytotoxic concentration: 370000 nM
Compound 4: the middle estimate sits 1.5-fold (0.17 log units) above what was measured, and the stated range covers the measured number.
By their numbers in this assay, from the lowest: compounds 3, 4, 2 and 1 (each within the scatter of the next, the first and the last beyond it).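

The exchange of 3-methylthiophen-2-yl for 5-methylfuran-2-yl on this saturated ring carbon, next to the ring nitrogen, gives a 1.7-fold lower number from compound 2 to compound 4 (0.22 log units; within the scatter) in this assay and so does not separate the two methylated rings. Among these compounds, measured from the thiophen-2-yl of compound 1, the same position gives a 2.7-fold lower number from compound 1 to compound 4 (0.43 log units; beyond the scatter), the first step at this position that goes beyond the scatter. No measurement at hand accounts for either step. The compounds shown leave open how an unsubstituted furan-2-yl would read here, and whether an amine or a carboxylic acid in place of the methyl would shift the number.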